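A few compounds are considered here, and "the series" means these few. Any claim that something is new, unique, unknown or untested is made for them only; others in the source may bear on it.

Series notes, one step.

Compound 1 `CC1=C(C(=O)Nc2ccc(F)c(Cl)c2)C(c2cccc(O)c2)NC(=S)N1` gives 22400 nM in a functional assay on COLO 205 cells (Homo sapiens) for cytotoxicity, read by sulforhodamine B assay, with a stated time of 48 h (a higher number here means a weaker inhibitor of growth, a lower number a stronger inhibitor of growth), the highest number among the three measured compounds. Compound 2 `CC1=C(C(=O)Nc2ccc(Cl)c(Cl)c2)C(c2cccc(Oc3ccccc3)c2)NC(=S)N1` gives 9330 nM in this assay, and compound 3 `CC1=C(C(=O)Nc2ccc(Cl)c(Cl)c2)C(c2cccc(O)c2)NC(=S)N1` gives 7080 nM. Within the data shown here, the one measured step from compound 1, a 3.2-fold lower number from compound 1 to compound 3 (0.50 log units; beyond the scatter), is the only change beyond the scatter in the set; the other step, a 1.3-fold lower number from compound 2 to compound 3 (0.12 log units; within the scatter), stays within it.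

Compound 4 `COc1cccc(C2NC(=S)NC(C)=C2C(=O)Nc2ccc(F)c(Cl)c2)c1` differs from compound 1 by methyl in place of hydrogen on an oxygen on an aromatic ring. Among the measured compounds shown here, the step that bears on this is the one from compound 2 to compound 3, where the oxygen on the aromatic ring carries phenyl in one and hydrogen in the other, and that pair is within the scatter. Hydroxy to methoxy is a smaller change at the same oxygen than phenyl to hydrogen, so no movement beyond the scatter is expected in this assay; the direction, if any, cannot be read from these three compounds.

For the measured compounds named here, the expected step is therefore a 1.0-fold lower number from compound 1 to compound 4 (0.01 log units; within the scatter), essentially flat, with the range kept wide because only one pair speaks to this position. Compound 4 is estimated at 22000 nM in this assay, between 9000 nM and 50000 nM.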

Compound 4, concentration for 50% growth inhibition: 26900 nM
Estimate against measurement, compound 4: 1.2-fold (0.09 log units) below, within the range that was stated.
By their numbers in this assay, from the lowest: compounds 3 and 2 (each within the scatter of the next); then compounds 1 and 4 (each within the scatter of the next).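

With methyl in place of hydrogen on the oxygen on the aromatic ring, a 1.2-fold higher number from compound 1 to compound 4 (0.08 log units; within the scatter) in this assay, so this oxygen now has a second pair within the scatter, and that pair carries the fluoro and chloro anilide rather than the dichloro anilide of the phenyl to hydrogen pair. Across these two pairs, a free hydroxy is not needed to hold the value in this assay, whether the oxygen carries methyl or phenyl, while a 3.2-fold lower number from compound 1 to compound 3 (0.50 log units; beyond the scatter) remains the only listed step beyond the scatter and sits on the halogen rather than on this oxygen. No measurement available here accounts for the flat result at this oxygen.

Still open, as far as these compounds go, is whether the oxygen itself matters, which an amine at the same place on the ring, or a carboxylic acid there, would test, and whether a longer chain such as butyl on the oxygen stays as flat as methyl and phenyl do. Also open, from the compounds shown here alone, is whether the chloro in place of fluoro step carries over to the 3-methoxyphenyl compounds, since that step is read only with the 3-hydroxyphenyl group.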